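A pyridin-4-yl variant of compound 1

The source may report more compounds than this note shows. Statements on the series, on what has been measured and on what is new or still open speak of the compounds shown alone.

Within the data shown here, compound 1 `CC(C)C[C@H](N)CN(C(=O)[C@@H]1C[C@H]1c1ccccc1)c1ccc(-c2ccccc2)cc1` gives 880 nM in a functional assay for agonist activity at G protein-coupled receptor 88 (Homo sapiens), read by HTRF and cAMP accumulation (on this read-out lower numbers stand for an effect already at smaller amounts and higher numbers for an effect only at larger amounts of compound), the highest of the two numbers measured so far. The other measured compound, compound 2 `O=C([C@@H]1C[C@H]1c1ccccc1)N(CCNCC1CCCCC1)c1ccc(-c2ccccc2)cc1`, gives 6.6 nM in this assay. Among the measured compounds shown here, the single measured step, a 130-fold lower number from compound 1 to compound 2 (2.12 log units; beyond the scatter), concerns a different place in the molecule, where ((cyclohexylmethyl)amino)methyl replaces 1-amino-3-methylbutyl on a saturated chain carbon bound to an amide-type nitrogen.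

Compound 3 `CC(C)C[C@H](N)CN(C(=O)[C@@H]1C[C@H]1c1ccccc1)c1ccc(-c2ccncc2)cc1` differs from compound 1 elsewhere: pyridin-4-yl in place of phenyl on an aromatic carbon. For the measured compounds named here, no measured step touches this aromatic carbon, so the step from compound 1 to compound 2 offers no direct guide, and no change beyond the scatter is expected in this assay. The step expected is a 1.1-fold higher number from compound 1 to compound 3 (0.06 log units; within the scatter). Compound 3 is therefore estimated at 1000 nM, with a range from 300 nM to 3500 nM.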

Compound 3, half-maximal effective concentration: 13000 nM
The estimate for compound 3 lay 13-fold (1.11 log units) below the measured number; measured number above the stated range.
By their numbers in this assay, from the lowest: compound 2; then compound 1; then compound 3.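

At this aromatic carbon, on a six-membered aromatic ring of carbon only and para to a large group, the core of compound 1 proves sensitive to a change of a single ring atom: in this assay, pyridin-4-yl in place of phenyl gives a 15-fold higher number from compound 1 to compound 3 (1.17 log units; beyond the scatter). The entering ring is also six-membered and aromatic, and the counted differences are its ring nitrogen and a hydrogen-bond acceptor, so even this small exchange moves the number well beyond the scatter. No available evidence accounts for the step.

The compounds shown do not tell whether pyridin-3-yl or pyrimidin-5-yl on the same carbon would give a step of similar size. From the compounds shown here alone, whether pyridin-4-yl would give a similar step alongside the ((cyclohexylmethyl)amino)methyl group of compound 2 also remains open.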